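The compounds below may be only part of what the source reports. "The series", "measured", "known", "first", "only" and "open" are said of these compounds alone.

Two compounds of this series have numbers in a functional assay on HeLa cells (Homo sapiens) for antiproliferative activity, read by CCK-8 assay, with a stated time of 72 h, tested at 2 uM; a lower number here means a weaker effect, a higher number a stronger effect of the compound at the concentration tested. Compound 1 `Nc1ccccc1NC(=O)c1ccc(CSC(=S)N2CCN(c3ccc(Cl)cc3)CC2)cc1` gives 51.2% in this assay, and compound 2 `Nc1ccccc1NC(=O)c1ccc(CSC(=S)N2CCN(c3ccc(F)cc3)CC2)cc1` gives 60.8%; the step of a number 9.6 percentage points higher from compound 1 to compound 2 (within the scatter) lies within the scatter, so compound 2 is not separated from compound 1 on these numbers, and neither can be called the more active of the two.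

Compound 3 `Nc1ccccc1NC(=O)c1ccc(CSC(=S)N2CCN(Cc3ccccc3)CC2)cc1` differs from compound 2 in one place: benzyl in place of 4-fluorophenyl on an amine nitrogen in a ring. For the measured compounds named here, the only measured step in this assay, from compound 1 to compound 2, concerns a halogen on the aromatic ring and not the exchange of an aromatic ring for a benzyl group on the ring nitrogen, so no measured step bears directly on this change. The expected step of a number 5.8 percentage points lower from compound 2 to compound 3 (within the scatter) is therefore none beyond the scatter, with a wide margin. For compound 3 the estimate in this assay is 55%, ranging from 35% to 75%.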

Compound 3, a percentage reported as inhibition, at one concentration (the size of the read-out at that concentration, not a potency): 20.6%
The estimate for compound 3 lay 34.4 percentage points above the measured number; the whole stated range lies above it.
By their numbers in this assay, from the lowest: compound 3; then compounds 1 and 2 (each within the scatter of the next).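

In this assay, the group on the amine nitrogen in the ring weighs far more than the halogen on the aromatic ring: benzyl in place of 4-fluorophenyl goes with a number 40.2 percentage points lower from compound 2 to compound 3 (beyond the scatter), and benzyl in place of 4-chlorophenyl goes with a number 30.6 percentage points lower from compound 1 to compound 3 (beyond the scatter). The leaving 4-fluorophenyl and the entering benzyl hold the same number of heavy atoms and one six-membered aromatic ring of carbon only, so these counts do not separate them. No measurement at hand accounts for the drop at this position.

Open, as far as these compounds go, is whether the low number belongs to benzyl alone or extends to other groups at this nitrogen, such as unsubstituted phenyl, phenethyl or a plain methyl. Also open, from the compounds shown here alone, is whether a fluoro or chloro substituent on the benzyl ring would change the number for compound 3.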